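Replacing 4-methylpiperazin-1-yl in compound 3

The compounds below may be only part of what the source reports. "The series", "measured", "known", "first", "only" and "open" are said of these compounds alone.

In an ADME assay on MRC5 cells (Homo sapiens) for antiproliferative activity, read by fluorescence and resazurin assay, with a stated time of 68 h (a higher number here means that more compound is needed for the effect, a lower number that less compound is needed), compound 1 (`Cc1ccc(-c2cc(C(=O)Nc3cccnc3)c3cc(F)ccc3n2)cc1`) reads 50000 nM and compound 2 (`Cc1ccc(-c2cc(C(=O)NCCN(C)C)c3cc(Cl)ccc3n2)cc1`) reads 9000 nM on the same scale. Compound 3 (`CN1CCN(c2cc(C(=O)NCCN3CCCC3)c3cc(F)ccc3n2)CC1`) reads 20000 nM and stands second highest of the three, beyond the scatter from both others. In compound 4 (`O=C(NCCN1CCCC1)c1cc(NCCC2CCOCC2)nc2ccc(F)cc12`) (2-(oxan-4-yl)ethyl)amino replaces 4-methylpiperazin-1-yl on an aromatic carbon next to the ring nitrogen ((2-(oxan-4-yl)ethyl)amino in place of 4-methylpiperazin-1-yl on an aromatic carbon). Going by the values given here, no measured pair differs in one place only, so the three values give only a broad spread to work from. A small move toward a lower number is expected, a 1.7-fold lower number from compound 3 to compound 4 (0.22 log units; within the scatter) in this assay and not beyond the scatter. For compound 4 the expected value is 12000 nM with 4000 nM to 40000 nM as the estimated range.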

Compound 4, half-maximal effective concentration: > 50000 nM
Compound 4 ended at the assay's limit; the forecaster's own chance of this, stated with the estimate: 15%; middle value at least 4.1-fold (0.61 log units) away from the limit.
By their numbers in this assay, from the lowest: compound 2; then compound 3; then compound 1.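

Replacing 4-methylpiperazin-1-yl with (2-(oxan-4-yl)ethyl)amino on this aromatic carbon next to the ring nitrogen gives an at least 2.5-fold higher number from compound 3 to compound 4 (0.39 log units; beyond the scatter) in this assay. Going by these compounds alone, this is the first single-place comparison, and it shows that the group at this position alters the reading, which the earlier compounds could not separate from their other differences. Compound 4 carries a limit rather than a number: the limit of > 50000 nM in this assay, at which 1 of the 4 values shown sits.

As far as these compounds go, the true size of the step stays open. So does whether morpholin-4-yl or a shorter aminoalkyl chain at this position would read nearer compound 3 or compound 4.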